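The compounds below may be only part of what the source reports. "The series", "measured", "known", "first", "only" and "open" are said of these compounds alone.

Of the compounds shown here, three sharing one core have been measured in an ADME assay (liver) for metabolic stability, with Liver microsome (Homo sapiens) as the target, read by LC-MS, using microsomes and NADPH, tested at 1 uM; on this read-out higher numbers stand for a longer-lived compound and lower numbers for a shorter-lived compound. Compound 1, `CC(C)(C)c1cc(NC(=O)[C@@H]2CCCCN2C2CC2)no1`, carries a cyclopropyl group on the ring nitrogen; in this assay compound 1 gives 0.183 h. Compound 2, `CC(C)(C)c1cc(NC(=O)[C@@H]2CCCCN2C2CCOCC2)no1`, carries an oxan-4-yl group there, and in this assay compound 2 gives 0.317 h. Compound 3, `CC(C)(C)c1cc(NC(=O)[C@@H]2CCCCN2C(=O)C2CCOCC2)no1`, carries an (oxan-4-yl)carbonyl group on that nitrogen. For compound 3 this assay reports only a limit, > 2 h, and this is the limit of > 2 h in this assay, at which 1 of the 3 values shown sits. The steps between the measured compounds read as follows: a 1.7-fold higher number from compound 1 to compound 2 (0.24 log units; within the scatter); an at least 10-fold higher number from compound 1 to compound 3 (1.03 log units; beyond the scatter); an at least 6.3-fold higher number from compound 2 to compound 3 (0.79 log units; beyond the scatter). The large movements thus belong to the two steps that bring in the carbonyl on the ring nitrogen, while the step between the two amines stays within the scatter.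

Compound 4, `CC(C)(C)c1cc(NC(=O)[C@@H]2CCCCN2C(=O)CC2CCOCC2)no1`, is not yet measured. Its difference from compound 3 is (oxan-4-yl)methyl in place of oxan-4-yl on a carbonyl carbon, so the carbonyl on the ring nitrogen is kept and the change sits one bond further out. Among the compounds with values here, no measured step alters that carbonyl-bearing group alone, so the only guide is that compound 3 already sits at the limit. For compound 4 an estimated value of 2.5 h (range 1 h to 6 h) is therefore expected, a step that the limit leaves unreadable from compound 3 to compound 4, with a fair chance that this assay again reports only a limit.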

Compound 4, half-life: 1.83 h
Beside the measured number, compound 4's estimate is 1.4-fold (0.14 log units) above it; measured number inside the range.
By their numbers in this assay, from the lowest: compounds 1 and 2 (each within the scatter of the next); then compound 4. At a limit, above all of these: compound 3.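

Compound 4 gives the series its first exact number for a carbonyl on the ring nitrogen in this assay, and that number stays well clear of both amines: a 5.8-fold higher number from compound 2 to compound 4 (0.76 log units; beyond the scatter) and a 10-fold higher number from compound 1 to compound 4 (1.00 log units; beyond the scatter), both beyond the scatter. The high readings of the carbonyl-bearing compounds therefore do not depend on oxan-4-yl sitting directly on the carbonyl carbon, since (oxan-4-yl)methyl at that place also keeps compound 4 apart from compound 1 and compound 2, and neither carbonyl compound goes against this pattern. The direct comparison gives an at least 1.0-fold lower number from compound 3 to compound 4 (0.03 log units; that floor lies within the scatter), a floor within the scatter, so no change can be claimed for this swap, and the true size of the step stays unread with compound 3 held at a limit: the limit of > 2 h in this assay, at which 1 of the 4 values shown sits.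

The compounds shown leave open whether a longer chain, such as (oxan-4-yl)ethyl, on the carbonyl carbon would hold the half-life at this level. They also do not tell whether the ring oxygen matters at all, as a cyclohexyl group in place of oxan-4-yl would show, or how an amine carried on that group would read.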